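The source may report more compounds than this note shows. Statements on the series, on what has been measured and on what is new or still open speak of the compounds shown alone.

Three compounds share one core and differ only in the aromatic group on a carbon with a double bond to nitrogen. Compound 1 `C[C@H](c1ccc(C(=O)NCCC(=O)O)cc1)N1C(=O)C(c2ccc(F)cc2)=N[C@]12CC[C@@H](C(C)(C)C)CC2` gives 85 nM in an assay on CHO cells for displacement of a labelled ligand from Glucagon receptor (Homo sapiens), read by scintillation counting, with a stated time of 60 min; on this read-out higher numbers stand for weaker inhibition and lower numbers for stronger inhibition. Compound 2 `C[C@H](c1ccc(C(=O)NCCC(=O)O)cc1)N1C(=O)C(c2cccc(C3CC3)c2)=N[C@]12CC[C@@H](C(C)(C)C)CC2` gives 56 nM, and the change a 1.5-fold lower number from compound 1 to compound 2 (0.18 log units; within the scatter) stays within the scatter. Compound 3 `C[C@H](c1ccc(C(=O)NCCC(=O)O)cc1)N1C(=O)C(c2cccc(OC(F)(F)F)c2)=N[C@]12CC[C@@H](C(C)(C)C)CC2` gives 330 nM, the highest number of the three, reached through a 3.9-fold higher number from compound 1 to compound 3 (0.59 log units; beyond the scatter) and a 5.9-fold higher number from compound 2 to compound 3 (0.77 log units; beyond the scatter). Compound 4 `C[C@H](c1ccc(C(=O)NCCC(=O)O)cc1)N1C(=O)C(c2cccc(Cl)c2F)=N[C@]12CC[C@@H](C(C)(C)C)CC2` carries 3-chloro-2-fluorophenyl in place of 3-(trifluoromethoxy)phenyl on a carbon with a double bond to nitrogen. Both steps into compound 3 raised the number, so removing its group is expected to lower it again, roughly back toward compound 1, giving an expected 3.7-fold lower number from compound 3 to compound 4 (0.56 log units; beyond the scatter). Compound 4 is therefore estimated at 90 nM, within a range from 35 nM to 250 nM.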

Compound 4, half-maximal inhibitory concentration: 620 nM
Compound 4: middle estimate off by 6.9-fold (0.84 log units), on the low side; the measured number lies above the stated range.
By their numbers in this assay, from the lowest: compounds 2 and 1 (each within the scatter of the next); then compounds 3 and 4 (each within the scatter of the next).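

The 3-chloro-2-fluorophenyl group does not bring the number back down: in this assay, a 1.9-fold higher number from compound 3 to compound 4 (0.27 log units; within the scatter) stays within the scatter, so losing the 3-(trifluoromethoxy)phenyl group does not by itself recover binding. Compound 4 stays clearly apart from the two best compounds, with an 11-fold higher number from compound 2 to compound 4 (1.04 log units; beyond the scatter) and a 7.3-fold higher number from compound 1 to compound 4 (0.86 log units; beyond the scatter), so the choice of aromatic group at this position matters. No available data bear on the reason. The compounds shown leave open how a plain phenyl group, or a ring carrying an amine, would read here, and whether the chlorine or the fluorine matters more in compound 4.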